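Benzofuran in Place of Methoxyphenyl on the Shared Core

A few compounds are considered here, and "the series" means these few. Any claim that something is new, unique, unknown or untested is made for them only; others in the source may bear on it.

Compound 1 `COC(=O)c1cccc(-c2ccc([C@H]3S[C@@H](C)C(=O)Nc4c3c(C)nn4-c3ccccc3C)cc2)c1`: "not active" (no number reported) in an assay on isolated protein for agonist activity at Bile acid receptor (Homo sapiens), read by AlphaScreen, with a stated time of 30 min (on this read-out lower numbers stand for an effect already at smaller amounts and higher numbers for an effect only at larger amounts of compound), no number reported
Compound 2 `COc1ccc(Oc2ccc([C@H]3S[C@@H](C)C(=O)Nc4c3c(C)nn4-c3ccccc3C)cc2)cc1`: 2200 nM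
Compound 3 `COc1cccc(-c2ccc([C@H]3S[C@@H](C)C(=O)Nc4c3c(C)nn4-c3ccccc3C)cc2)c1`: 1800 nM

Of the two numbers on record, compound 3 has the lower one; its nearest neighbour is compound 2, and the step of a 1.2-fold lower number from compound 2 to compound 3 (0.09 log units; within the scatter) lies within the scatter. Compound 1 gave no number at all in this assay.

Compound 4 `Cc1ccccc1-n1nc(C)c2c1NC(=O)[C@H](C)S[C@@H]2c1ccc(-c2cc3ccccc3o2)cc1` differs from compound 3 by 1-benzofuran-2-yl in place of 3-methoxyphenyl on an aromatic carbon. For the measured compounds named here, no measured step touches the benzofuran; the only step on record, from compound 2 to compound 3, is within the scatter, so nothing indicates a shift beyond the scatter in either direction. Compound 4 is therefore expected near compound 3, with no change at the digits printed from compound 3 to compound 4 (within the scatter) as the estimated step, at 1800 nM within 500 nM to 6000 nM.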

Compound 4, half-maximal effective concentration: 1500 nM
Compound 4: middle estimate off by 1.2-fold (0.08 log units), on the high side, within the range that was stated.
By their numbers in this assay, from the lowest: compounds 4, 3 and 2 (each within the scatter of the next).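

Putting 1-benzofuran-2-yl at this aromatic carbon gives a 1.2-fold lower number from compound 3 to compound 4 (0.08 log units; within the scatter) and a 1.5-fold lower number from compound 2 to compound 4 (0.17 log units; within the scatter) in this assay, so a group with a five-membered aromatic ring joins 3-methoxyphenyl and 4-methoxyphenoxy within the scatter of one another. Compound 1 goes against this flat picture, and steps to it cannot be read, as it gave no number. No supporting data bear on this result.

Going by these compounds, it remains open how an amine or a carboxylic acid at this carbon would read, and what separates compound 1 from the other three.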